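The source may hold more compounds than are shown below. What is called first, only, known or untested is meant among the compounds shown, and "the series" means these compounds.

Measured so far in a functional assay on the whole organism (strain Wistar) for inhibition, with Rattus norvegicus as the target, read by paw edema, with a stated time of 4 h, at a dose of 10 mg/kg by the oral route; a lower number here means less inhibition, a higher number more inhibition at the dose given (going by the name of the read-out):
- compound 1, `Clc1ccccc1-c1nnc(COc2ccc(-c3ccccc3)cc2)o1`: 63.6%
- compound 2, `Clc1ccc(-c2nnc(COc3ccc(-c4ccccc4)cc3)o2)c(Cl)c1`: 57.6%

Compound 2 has the lowest of the two numbers in this assay, and its nearest neighbour is compound 1, whose value sits higher only within the scatter, so no order between the two can be claimed. Compound 3, `CCCCNc1nnc(COc2ccc(-c3ccccc3)cc2)o1`, is still to be measured. It differs from compound 2 in one place: butylamino in place of 2,4-dichlorophenyl on an aromatic carbon. Going by the values given here, the only measured step, a number 6 percentage points lower from compound 1 to compound 2 (within the scatter), touches the same ring that now leaves entirely, but it adds a single chloro to it and stays within the scatter, so it says little about exchanging the whole ring for a chain bearing a nitrogen. Among the compounds with values here, with no closer step to lean on, the expected change is uncertain and the range must be wide; a step of a number 9.6 percentage points lower from compound 2 to compound 3 (within the scatter) is expected. Compound 3 is therefore estimated at 48%, between 22% and 70%.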

Compound 3, a percentage reported as inhibition, in the whole organism at one dose (the size of the read-out at that dose, not a potency): 15.9%
Estimate against measurement, compound 3: 32.1 percentage points above, and the stated range ends above it.
By their numbers in this assay, from the lowest: compound 3; then compounds 2 and 1 (each within the scatter of the next).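

In this assay, the aromatic carbon of the five-membered ring proves highly sensitive to what it carries: butylamino in place of 2,4-dichlorophenyl gives a number 41.7 percentage points lower from compound 2 to compound 3 (beyond the scatter), and butylamino in place of 2-chlorophenyl gives a number 47.7 percentage points lower from compound 1 to compound 3 (beyond the scatter). The earlier step, which added a single chloro to the ring at this place, stayed within the scatter, whereas exchanging the whole aromatic ring for this chain produces a large step. No measurement here explains why the number falls so far.

The exchange removes the ring and brings in a nitrogen in one move, so the compounds shown cannot separate these two parts. A plain butyl chain on the same carbon, or a cyclohexylamino group there, would help tell them apart.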